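Furan Ring Replaces an Alkene Group on a Cyanoguanidine

A few compounds are considered here, and "the series" means these few. Any claim that something is new, unique, unknown or untested is made for them only; others in the source may bear on it.

Compound 1 `CCCC(C)(C)/N=C(\NC#N)Nc1cccnc1`: 1 mg/kg
Compound 2 `C=C(C)C/N=C(\NC#N)Nc1cccnc1`: 20 mg/kg

Both compounds were tested in a functional assay on the whole organism (blood, strain Wistar-Okamoto) with Rattus norvegicus as the target, with a stated time of 5 days; on this read-out higher numbers stand for an effect only at larger amounts of compound and lower numbers for an effect already at smaller amounts. Compound 2 gives the highest of the two numbers in this assay; its nearest neighbour is compound 1, from which it is separated by a 20-fold higher number from compound 1 to compound 2 (1.30 log units; beyond the scatter). That single step, exchanging the group on the double-bonded nitrogen, is the only one measured, and it shows that this position can move the read-out a great deal.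

Compound 3 `N#CN/C(=N\Cc1ccco1)Nc1cccnc1` has not been measured. It differs from compound 2 in furan-2-yl in place of 1-methylethenyl on a saturated chain carbon bound to a double-bonded nitrogen; cut one bond further out, the change reads 2-methylprop-2-en-1-yl to (furan-2-yl)methyl. For the measured compounds named here, only the step from compound 1 to compound 2 bears on this change, and it concerns a different group at the same place, so its direction cannot simply be carried over. Given how large a 20-fold higher number from compound 1 to compound 2 (1.30 log units; beyond the scatter) was, a step of some size is expected, but the data give no firm direction. Compound 3 is therefore estimated at 10 mg/kg (range 2 mg/kg to 50 mg/kg), a change of a 2.0-fold lower number from compound 2 to compound 3 (0.30 log units; within the scatter).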

Compound 3, minimum effective dose: 20 mg/kg
Estimate against measurement, compound 3: 2.0-fold (0.30 log units) below; the range from low to high includes it.
By their numbers in this assay, from the lowest: compound 1; then compounds 2 and 3 (each within the scatter of the next).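

In this assay, furan-2-yl in place of 1-methylethenyl on a saturated chain carbon bound to a double-bonded nitrogen gives no change at the digits printed from compound 2 to compound 3 (within the scatter), so a five-membered aromatic ring with one hetero atom stands at this place with no visible effect on the read-out. The step from 1,1-dimethylbutyl to (furan-2-yl)methyl on the double-bonded nitrogen gives a 20-fold higher number from compound 1 to compound 3 (1.30 log units; beyond the scatter), which matches a 20-fold higher number from compound 1 to compound 2 (1.30 log units; beyond the scatter) at the digits printed, so the large gap from compound 1 is now seen with two different groups and is not tied to 2-methylprop-2-en-1-yl alone. Nothing at hand offers an explanation for either step.

The compounds shown leave open which part of 1,1-dimethylbutyl goes with the lower number of compound 1, a question on which a plain butyl chain, a tert-butyl group or a longer branched alkyl chain on the same nitrogen would bear. As far as these compounds go, it also remains open whether a phenyl or thiophen-2-yl ring, or a chain carrying an amine, on the saturated chain carbon would read like furan-2-yl.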